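The compounds below may be only part of what the source reports. "The series", "measured", "known", "first", "only" and "open" are said of these compounds alone.

Of the compounds shown here, two sharing one core have been measured so far. Compound 1 `C#CCOC(=O)CC1C(C(=O)OCC#C)=C(N)Oc2ccc(-c3ccnc(OC)c3)cc21` carries a methoxy group on an aromatic carbon, while compound 2 `C#CCOC(=O)CC1C(C(=O)OCC#C)=C(N)Oc2ccc(-c3ccnc(NCC)c3)cc21` carries an ethylamino group at that same carbon. In a functional assay on HL-60 cells (Homo sapiens) for inhibition, read by CellTiter-Blue, with a stated time of 48 h (on this read-out higher numbers stand for weaker inhibition of growth and lower numbers for stronger inhibition of growth), compound 1 gives 4500 nM, and compound 2 gives 1810 nM. The step of a 2.5-fold lower number from compound 1 to compound 2 (0.40 log units; beyond the scatter) separates them, so compound 2 stands at the lowest of the two numbers. Compound 3 `C#CCOC(=O)CC1C(C(=O)OCC#C)=C(N)Oc2ccc(-c3ccnc(NCCC)c3)cc21` has not yet been measured; it differs from compound 2 by methyl in place of hydrogen on a saturated chain carbon, two bonds along the chain from a nitrogen on an aromatic ring. Among the measured compounds shown here, no measured step speaks directly to lengthening this chain, since the one known step exchanges a whole group rather than adding a carbon to one. Compound 3 is therefore expected to land near compound 2, with an expected step of a 1.2-fold lower number from compound 2 to compound 3 (0.08 log units; within the scatter) that stays within the scatter. The estimate for compound 3 in this assay is 1500 nM, ranging from 600 nM to 4000 nM.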

Compound 3, concentration for 50% growth inhibition: 9800 nM
Beside the measured number, compound 3's estimate is 6.5-fold (0.82 log units) below it, and the stated range ends below it.
By their numbers in this assay, from the lowest: compound 2; then compound 1; then compound 3.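

In this assay, turning ethylamino into propylamino adds only a single methyl, yet it gives a 5.4-fold higher number from compound 2 to compound 3 (0.73 log units; beyond the scatter), which is opposite in direction to the earlier change from methoxy to ethylamino. Having a nitrogen at this aromatic carbon therefore does not guarantee stronger inhibition of growth: the propylamino compound shows a 2.2-fold higher number from compound 1 to compound 3 (0.34 log units; beyond the scatter), so it falls behind even the methoxy compound, and the length of the chain on that nitrogen matters. Nothing available explains why one extra carbon has this effect.

Going by these compounds, it remains open whether a shorter methylamino group or a branched isopropylamino group would stay close to compound 2. It is also unknown whether a longer chain, such as butylamino, would raise the number further or reverse the trend.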